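The source may hold more compounds than are shown below. What is called first, only, known or untested is meant among the compounds shown, and "the series" means these compounds.

Compound 1, `Cc1nnc(SCc2cc(=O)c3cc(Cl)ccc3o2)o1`: > 25000 nM
Compound 2, `Cc1ccc2oc(CSc3nnc(C)s3)cc(=O)c2c1`: > 25000 nM

Both numbers come from a functional assay on LM7 cells (Homo sapiens) for cytotoxicity, read by MTT assay, with a stated time of 72 h; on this read-out lower numbers stand for stronger inhibition and higher numbers for weaker inhibition. The value given for compound 1 is a limit of the assay, not a number. The value given for compound 2 is likewise a limit of the assay. Within the data shown here, compound 2 therefore stands at the top of the range that the measurement can report, and the only other compound measured stands there with it (the limit of > 25000 nM in this assay, at which 2 of the 2 values shown sit). Among the measured compounds shown here, no pair of measured compounds differs in a single place, so no measured step is available to lean on.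

The unmeasured compound 3, `Cc1nnc(SCc2cc(=O)c3cc(Cl)ccc3o2)s1`, is built from compound 2 by one change: chloro in place of methyl on an aromatic carbon. With both measured compounds sitting at the same limit, the change from compound 2 to compound 3 is expected to give a step that the limit leaves unreadable from compound 2 to compound 3 that is no larger than the scatter and in no particular direction. Compound 3 is accordingly estimated at 30000 nM, with a range from 10000 nM to 100000 nM, and most likely the assay will again report only a limit.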

Compound 3, half-maximal inhibitory concentration: > 25000 nM
Compound 3: no number, only a limit; the forecaster's own chance of this, stated with the estimate: 80%; the middle value does not contradict the limit.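

In this assay compound 3 gives > 25000 nM, which is a limit of the assay and not a number. No step from compound 1 or compound 2 to compound 3 can therefore be read: the limit of > 25000 nM in this assay, at which 3 of the 3 values shown sit.

The compounds shown leave open whether chloro in place of methyl, or 5-methyl-1,3,4-thiadiazol-2-yl in place of 5-methyl-1,3,4-oxadiazol-2-yl, changes cytotoxicity at all.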